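The compounds below may be only part of what the source reports. "The series", "measured", "known", "first", "only" and "open" are said of these compounds alone.

Of the compounds shown here, two built on one shared core have so far been tested in an assay on HEK293 cells for binding affinity to 5-hydroxytryptamine receptor 7 (Homo sapiens), read by radioligand binding; on this read-out lower numbers stand for stronger inhibition and higher numbers for weaker inhibition. Compound 1 `CN1CCCN(CCn2ccc3ccc(Br)cc32)CC1` carries a bromo group on its aromatic ring, and in this assay compound 1 gives 31 nM. Compound 2 `CN1CCCN(CCn2ccc3ccc(C(F)(F)F)cc32)CC1` carries a trifluoromethyl group instead, and in this assay compound 2 gives 23 nM. For the measured compounds named here, of these two numbers, the one for compound 1 is the higher, yet the step of a 1.3-fold lower number from compound 1 to compound 2 (0.13 log units; within the scatter) lies within the scatter, so the two compounds cannot be separated on this evidence.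

Compound 3 `Cc1ccc2ccn(CCN3CCCN(C)CC3)c2c1` has not yet been measured. It differs from compound 1 in one place: methyl in place of bromo on an aromatic carbon. Going by the values given here, the only measured step that bears on this change is the exchange of bromo for trifluoromethyl, a 1.3-fold lower number from compound 1 to compound 2 (0.13 log units; within the scatter), which stayed within the scatter. With that single comparison in hand, the expectation for the exchange of bromo for methyl is likewise a step within the scatter, with no direction to claim. The expected step is therefore a 1.1-fold higher number from compound 1 to compound 3 (0.05 log units; within the scatter). Compound 3 is thus estimated at 35 nM, within a range from 12 nM to 100 nM.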

Compound 3, inhibition constant: 125 nM
Beside the measured number, compound 3's estimate is 3.6-fold (0.55 log units) below it; measured number outside the range, above it.
By their numbers in this assay, from the lowest: compounds 2 and 1 (each within the scatter of the next); then compound 3.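

In this assay, this place on the aromatic ring proves sensitive to which group it carries: methyl in place of bromo gives a 4.0-fold higher number from compound 1 to compound 3 (0.61 log units; beyond the scatter), and methyl in place of trifluoromethyl gives a 5.4-fold higher number from compound 2 to compound 3 (0.74 log units; beyond the scatter), both beyond the scatter, whereas the earlier exchange of bromo for trifluoromethyl did not separate compound 1 from compound 2. The change from compound 1 to compound 3 is small on paper, with one heavy atom leaving, one entering, and no change in ring count, hydrogen-bond donors, hydrogen-bond acceptors or net charge, so these counts alone do not predict the shift seen here. No measurement at hand accounts for the difference.

For the compounds shown here, with only three groups compared at this place, it remains open whether a chloro, methoxy or amino group would give a number close to those of compound 1 and compound 2 or one close to that of compound 3. Also open, from the compounds shown here alone, is whether the same gap between bromo and methyl would persist with a longer chain joining the two halves of the molecule.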